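A few compounds are considered here, and "the series" means these few. Any claim that something is new, unique, unknown or untested is made for them only; others in the source may bear on it.

Measured compounds:
- compound 1, `O=C(/C=C/c1ccccc1)Nc1ccc2ncnc(Nc3cccc(Br)c3)c2c1`: 1.45 ug/mL
- compound 2, `O=C(/C=C/c1ccc(Cl)cc1)Nc1ccc2ncnc(Nc3cccc(Cl)c3)c2c1`: 9.97 ug/mL

Both were tested in a functional assay on B16-F10 cells (Mus musculus) for inhibition, read by MTT assay, with a stated time of 48 h; a higher number here means a weaker inhibitor, a lower number a stronger inhibitor. Compound 2 has the higher of the two numbers, and compound 1, with 1.45 ug/mL, sits clearly lower, a gap that goes beyond the usual scatter; the two differ in more than one place, so no single step can be read out of them.

Compound 3, `COc1cccc(/C=C/C(=O)Nc2ccc3ncnc(Nc4cccc(Cl)c4)c3c2)c1`, has not yet been measured. It is built from compound 2 by one change: 3-methoxyphenyl in place of 4-chlorophenyl on a double-bonded chain carbon bound to a double-bonded chain carbon. The rest of the shared core, including the chlorine-bearing aniline side, stays as it is in compound 2.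

Going by the values given here, there is no measured pair that shows this particular change on its own, so the expectation rests only on the spread between compound 1 and compound 2. The step from compound 2 to compound 3 is expected to be modest, a 1.7-fold lower number from compound 2 to compound 3 (0.22 log units; within the scatter), leaning toward a somewhat lower number but possibly staying inside the scatter. Compound 3 is therefore estimated at 6 ug/mL, with a likely range from 2 ug/mL to 18 ug/mL.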

Compound 3, half-maximal inhibitory concentration: 1.05 ug/mL
The estimate for compound 3 lay 5.7-fold (0.76 log units) above the measured number; the whole stated range lies above it.
By their numbers in this assay, from the lowest: compounds 3 and 1 (each within the scatter of the next); then compound 2.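

In this assay, replacing 4-chlorophenyl with 3-methoxyphenyl on a double-bonded chain carbon bound to a double-bonded chain carbon gives a 9.5-fold lower number from compound 2 to compound 3 (0.98 log units; beyond the scatter), so a change at this place alone can shift the number by more than the usual scatter. Compound 1 and compound 2 could not show this, since they differ in more than one place and their gap cannot be assigned to any single group; here the rest of the molecule, including the chlorine-bearing aniline side, stays the same. Nothing available here explains why the number falls, so the step records an outcome and not a reason.

The swap changes both the substituent on the ring and where it sits, so the compounds shown cannot say which of the two matters, and a 4-methoxyphenyl group at this place would help to separate them. As far as these compounds go, it also remains open how this place would respond to a ring carrying a very different group, such as an amine or a carboxylic acid.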